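Working notes: tert-butyl to ethyl in the series

This account rests on a few compounds, and the source may have more. Where it says the series, first, only, none or still open, it means among the compounds named here.

Measured so far:
- compound 1 `Cc1cc(=O)c2c(O)cc(OCc3ccccc3Br)c([C@H]3CCN(C)C[C@H]3O)c2o1`: 45%
- compound 2 `Cc1cc(=O)c2c(O)c(CN3CCN(C(=O)OC(C)(C)C)CC3)c(O)c([C@H]3CCN(C)C[C@H]3O)c2o1`: 16%

In a functional assay on MCF7 cells (Homo sapiens) for inhibition, read by MTT assay, with a stated time of 48 h, tested at 10 uM (a higher number here means more inhibition of growth at the concentration tested, a lower number less inhibition of growth), compound 2 holds the lower of the two numbers, and compound 1 lies higher by more than the scatter. Compound 3 `CCOC(=O)N1CCN(Cc2c(O)c([C@H]3CCN(C)C[C@H]3O)c3oc(C)cc(=O)c3c2O)CC1` differs from compound 2 by ethyl in place of tert-butyl on an oxygen next to a carbonyl group. Going by the values given here, no measured pair shows this change, so any expectation stays loose. No step beyond the scatter is expected in this assay, with compound 2 at 16% as the only measured reference carrying this side chain. The estimated change is a number 2 percentage points higher from compound 2 to compound 3 (within the scatter) (within the scatter). Compound 3 is expected at 18% (range 5% to 35%).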

Compound 3, percent growth inhibition at one concentration: 31%
Beside the measured number, compound 3's estimate is 13 percentage points below it; the measured number falls inside the stated range.
By their numbers in this assay, from the lowest: compound 2; then compound 3; then compound 1.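

In this assay, the side chain on this oxygen is not a silent position: ethyl in place of tert-butyl on an oxygen next to a carbonyl group gives a number 15 percentage points higher from compound 2 to compound 3 (beyond the scatter). This single pair gives the size of one change at one position and no trend. No available evidence bears on the origin of the step.

As far as these compounds go, what methyl, a longer chain such as n-butyl, or a free amine in place of ethoxycarbonyl would give remains open. So does whether the step carries over to other members of the series.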